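The source may hold more compounds than are shown below. What is called first, only, known or untested is meant among the compounds shown, and "the series" means these compounds.

Working notes on a small set of compounds tested in an assay on isolated protein for inhibition of alpha-ketoglutarate-dependent dioxygenase alkB homolog 3 (Homo sapiens), read by polymerase chain reaction, with a stated time of 1 h; on this read-out lower numbers stand for stronger inhibition and higher numbers for weaker inhibition.

Compound 1 `Cc1[nH]n(-c2nc3cc(C(C)(C)C)ccc3[nH]2)c(=O)c1Cc1ccccc1` gives 640 nM in this assay. Among the three numbers in hand this is the second highest. Compound 2 `Cc1nn(-c2nc3ccccc3[nH]2)c(O)c1Cc1ccccc1` gives 480 nM in this assay, a value that sits within the usual scatter of that of compound 1, so the two cannot be told apart on this read-out. Compound 3 `Cc1[nH]n(-c2nc3ccccc3[nH]2)c(=O)c1CC(=O)O` gives 15000 nM in this assay, a clearly higher number than that of compound 1 and well beyond the scatter; it is the furthest of the three from compound 1.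

Compound 4 `Cc1[nH]n(-c2nc3cc(-c4ccccc4)ccc3[nH]2)c(=O)c1Cc1ccccc1` has not yet been measured in this assay. It differs from compound 1 in one place: phenyl in place of tert-butyl on an aromatic carbon. Among the compounds with values here, no pair of measured compounds in this set differs in this one place, so the expectation for the step rests only on the values of compound 1 and compound 2, which lie within the scatter of each other. The expected step from compound 1 to compound 4 in this assay is a 1.2-fold lower number from compound 1 to compound 4 (0.07 log units; within the scatter), that is, none beyond the scatter in either direction. For compound 4 the estimate in this assay is 550 nM, with a range from 150 nM to 2000 nM.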

Compound 4, half-maximal inhibitory concentration: 810 nM
The estimate for compound 4 lay 1.5-fold (0.17 log units) below the measured number, within the range that was stated.
By their numbers in this assay, from the lowest: compounds 2, 1 and 4 (each within the scatter of the next); then compound 3.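

In this assay, within the data shown here, phenyl in place of tert-butyl on this aromatic carbon gives a 1.3-fold higher number from compound 1 to compound 4 (0.10 log units; within the scatter) and is the first matched step read at this position of the series. The position therefore carries either group with no change this read-out can resolve, even though phenyl brings more heavy atoms than tert-butyl and adds a six-membered aromatic ring of carbon only, so for this pair neither the added ring nor the loss of tert-butyl moves the number beyond the scatter. Nothing at hand accounts for the two groups reading alike, and the result stands as an observation on this one pair only.

On these data alone, both groups contain carbon only and carry no hydrogen-bond donors or acceptors, so it stays open whether an amine, a carboxylic acid or a methoxy group on this aromatic carbon would read any differently. As far as these compounds go, it also stays open whether a much smaller substituent, such as a methyl group or a chlorine atom, or a longer chain ending in an amide, would leave the number as unchanged as phenyl does.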